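Replacing the imidazolyl group of compound 2

The compounds below may be only part of what the source reports. "The series", "measured", "known", "first", "only" and "open" are said of these compounds alone.

Measured in a physicochemical assay for solubility, read by LC-MS, in phosphate buffer, with a stated time of 24 h, at pH 7.4; on this read-out lower numbers stand for lower solubility and higher numbers for higher solubility:
- compound 1 `Cc1ncccc1-c1cnc(NCc2c(F)ccc3c2CCO3)c2nn(CC#N)c(=O)n12`: 4000 nM
- compound 2 `Cc1nccn1-c1cnc(NCc2c(F)ccc3c2CCO3)c2cn[nH]c(=O)c12`: 7000 nM
- compound 3 `O=C1c2ccccc2CN1c1cnc(NCc2c(F)ccc3c2CCO3)n2cnnc12`: 4000 nM

The three compounds form a narrow set. Compound 2 gives 7000 nM, and this value lies within the usual scatter of both other measurements, so it cannot be separated from either of them. Compound 1 and compound 3 share the same number, although their cores differ from each other and from that of compound 2.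

The next compound is compound 4 `CC(=O)N1CCC(c2cnc(NCc3c(F)ccc4c3CCO4)c3cn[nH]c(=O)c23)CC1`. It keeps the core of compound 2 and carries 1-acetylpiperidin-4-yl in place of 2-methyl-1H-imidazol-1-yl on an aromatic carbon. Within the data shown here, no pair of measured compounds differs in one place only, so the data hold no direct precedent for this exchange.

Among the measured compounds shown here, the only guide is the narrow spread of the set, in which compound 1 gives 4000 nM and compound 3 gives 4000 nM. In this assay, no change beyond the scatter is therefore expected, and no firm direction can be assigned. The estimated step is a 1.1-fold higher number from compound 2 to compound 4 (0.06 log units; within the scatter). For compound 4 the expected value is 8000 nM, with an estimated range from 2500 nM to 25000 nM.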

Compound 4, solubility: < 2000 nM
Compound 4: only a limit was reported; the forecaster's own chance of this, stated with the estimate: 5%; at least 4.0-fold (0.60 log units) between middle value and limit.
By their numbers in this assay, from the lowest: compounds 1, 3 and 2 (each within the scatter of the next). At a limit, below all of these: compound 4.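

In this assay, among these compounds, putting 1-acetylpiperidin-4-yl in place of 2-methyl-1H-imidazol-1-yl on this aromatic carbon, with the core kept, gives an at least 3.5-fold lower number from compound 2 to compound 4 (0.54 log units; beyond the scatter); this is the first comparison in the set between compounds that differ in one place, and it shows that the read-out can move beyond the scatter with a change at this position. Compound 4 gave only a limit, not a number, so the step fixes a smallest size and leaves the full size unknown: the limit of < 2000 nM in this assay, at which 1 of the 4 values shown sits. The exchange also alters several features at once, as a five-membered aromatic ring gives way to a six-membered non-aromatic ring and a double bond outside aromatic rings enters, and this single step cannot separate them.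

The compounds shown leave open whether the shift follows the loss of the aromatic ring or the acetyl group, which a piperidin-4-yl group with a free amine or a phenyl group on the same carbon could help to separate. They also leave open whether the same exchange would give a similar step on the core of compound 1 or of compound 3.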